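Shifting the Fluorine on a Cytotoxic Compound

This account rests on a few compounds, and the source may have more. Where it says the series, first, only, none or still open, it means among the compounds named here.

Compound 1 `COc1ccc2[nH]c(-c3cccc(F)c3)cc(=O)c2c1OC`: 1300 nM
Compound 2 `COc1ccc2[nH]c(-c3ccccc3F)cc(=O)c2c1O`: 70 nM

Both values come from a functional assay on HL-60 cells (Homo sapiens) for cytotoxicity, read by MTT assay, with a stated time of 48 h; on this read-out lower numbers stand for stronger inhibition and higher numbers for weaker inhibition. Compound 2 holds the lower number of the two at 70 nM, while compound 1 gives 1300 nM, and the gap between them lies beyond the scatter. Going by the values given here, these two compounds differ in more than one place, so their gap offers no single step to carry over.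

Compound 3 `COc1ccc2[nH]c(-c3cccc(F)c3)cc(=O)c2c1O` awaits measurement. It has 3-fluorophenyl in place of 2-fluorophenyl on an aromatic carbon, and the rest of compound 2 stays the same. Among the compounds with values here, no measured pair shows this exchange alone, so the expectation rests on compound 2 at 70 nM, and no change beyond the scatter is expected in either direction. The expected step is a 1.2-fold lower number from compound 2 to compound 3 (0.07 log units; within the scatter). For compound 3 the estimated value is 60 nM, within a range of 15 nM to 250 nM.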

Compound 3, half-maximal inhibitory concentration: 30 nM
Compound 3: the middle estimate sits 2.0-fold (0.30 log units) above what was measured; the range from low to high includes it.
By their numbers in this assay, from the lowest: compound 3; then compound 2; then compound 1.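

In this assay the exchange of 2-fluorophenyl for 3-fluorophenyl gives a 2.3-fold lower number from compound 2 to compound 3 (0.37 log units; beyond the scatter) and so shows that the place of the fluorine on this ring counts, even though the two groups have the same atoms. Hydrogen in place of methyl on an oxygen on an aromatic ring gives a 43-fold lower number from compound 1 to compound 3 (1.64 log units; beyond the scatter) with 3-fluorophenyl held fixed. This second step is large and the first modest, so with this ring in place the methyl on that oxygen costs far more than the shift of the fluorine does.

Going by these compounds, it remains open how a chlorine, a nitrile or an amine in place of the fluorine on this ring would read, or a longer chain on that oxygen. Nothing in the data at hand accounts for either step.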